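The source may report more compounds than this note shows. Statements on the series, on what has been measured and on what is new or still open speak of the compounds shown alone.

Measured compounds:
- compound 1 `COC(=O)C1=C(C)N=C(C)/C(=C(\O)OC)C1c1cccc(N(C)C)c1`: 891 nM
- compound 2 `COC(=O)C1=C(C)N=C(C)/C(=C(\O)OC)C1c1cccc(Br)c1`: 1.29 nM
- compound 3 `COC(=O)C1=C(C)N=C(C)/C(=C(\O)OC)C1c1cccc(OC(C)=O)c1`: 6030 nM

In a functional assay (muscle tissue) with Cavia porcellus as the target (on this read-out lower numbers stand for an effect already at smaller amounts and higher numbers for an effect only at larger amounts of compound), compound 2 gives the lowest of the three numbers. The step of a 690-fold lower number from compound 1 to compound 2 (2.84 log units; beyond the scatter) and the step of a 4700-fold higher number from compound 2 to compound 3 (3.67 log units; beyond the scatter) both show that exchanging the group on the aromatic ring of compound 2 moves the number a great deal, and each step away from the bromo compound runs toward higher numbers. The smaller step of a 6.8-fold higher number from compound 1 to compound 3 (0.83 log units; beyond the scatter) shows that the two replacements differ from each other as well.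

Compound 4 `COC(=O)C1=C(C)N=C(C)/C(=C(\O)OC)C1c1ccc(C#N)cc1` is not yet measured. It differs from compound 2 in this way: 4-cyanophenyl in place of 3-bromophenyl on a saturated ring carbon. Among the compounds with values here, no measured pair shares this change; the two steps from compound 2 only show that any replacement of the bromo group seen so far has given a much higher number in this assay. The account therefore expects a large step toward higher numbers for compound 4, of the order of a 230-fold higher number from compound 2 to compound 4 (2.37 log units; beyond the scatter), with wide uncertainty. For compound 4 the estimated value in this assay is 300 nM, expected to lie between 30 nM and 3000 nM.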

Compound 4, half-maximal effective concentration: 3470 nM
The estimate for compound 4 lay 12-fold (1.06 log units) below the measured number; measured number outside the range, above it.
By their numbers in this assay, from the lowest: compound 2; then compound 1; then compounds 4 and 3 (each within the scatter of the next).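

In this assay, the replacement at this saturated ring carbon brings a 2700-fold higher number from compound 2 to compound 4 (3.43 log units; beyond the scatter), so the low number of compound 2 is lost here too, now with a change that swaps both the group on the phenyl ring and its place on that ring. Among the compounds shown, compound 2 therefore remains alone at the low end, and each of the three changes away from 3-bromophenyl leads to a higher number, with no compound going against this. Nothing at hand explains the size of this step.

Since 4-cyanophenyl differs from 3-bromophenyl in two ways at once, the compounds shown leave open how much of the step belongs to the nitrile and how much to where it sits on the phenyl ring. As far as these compounds go, it also stays open whether a chloro, methyl or methoxy group in the place of the bromo would keep a number close to that of compound 2, or whether the low number is particular to bromo among such groups.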